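Hydroxyphenyl ketone in place of methoxyphenyl on a chalcone

The source may hold more compounds than are shown below. What is called first, only, known or untested is meant among the compounds shown, and "the series" means these compounds.

Two compounds have been measured in a functional assay, read by Griess assay, with a stated time of 2.5 h; a lower number here means a stronger inhibitor, a higher number a weaker inhibitor:

- compound 1 `COc1ccc(C(=O)/C=C/c2cc(OC)c(OC)cc2OC)cc1` gives 2.07 ug/mL
- compound 2 `COc1cc(OC)c(OC)cc1/C=C/C(=O)c1ccc(-c2c[nH]cn2)cc1` gives 1.97 ug/mL

Among the compounds with values here, compound 1 has the highest of the two numbers, yet the only step, a 1.1-fold lower number from compound 1 to compound 2 (0.02 log units; within the scatter), puts compound 2 within the scatter of compound 1, so nothing separates them.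

Compound 3 `COc1cc(OC)c(OC)cc1/C=C/C(=O)c1cc(O)ccc1O` has not been measured in this assay. It differs from compound 1 in one place: 2,5-dihydroxyphenyl in place of 4-methoxyphenyl on a carbonyl carbon. Within the data shown here, the one measured step bears on this only loosely: it altered the same ring on the carbonyl carbon, swapping one group at one spot, and the number did not move beyond the scatter. Among the measured compounds shown here, the change to compound 3 is larger, replacing the whole ring, and no measured compound carries a hydroxyl. The expected step is therefore a 1.0-fold higher number from compound 1 to compound 3 (0.01 log units; within the scatter), that is, no clear movement beyond the scatter. Compound 3 is estimated at 2.1 ug/mL, within a range from 0.7 ug/mL to 6 ug/mL.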

Compound 3, half-maximal inhibitory concentration: 2.44 ug/mL
For compound 3 the middle estimate is 1.2-fold (0.07 log units) below the measured one, and the stated range covers the measured number.
By their numbers in this assay, from the lowest: compounds 2, 1 and 3 (each within the scatter of the next).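

Replacing the whole ring on the carbonyl carbon, rather than one group on it, gives in this assay a 1.2-fold higher number from compound 1 to compound 3 (0.07 log units; within the scatter) and so leaves 2,5-dihydroxyphenyl and 4-methoxyphenyl indistinguishable here. Compound 3 is also the first compound shown with hydroxyl groups, and its 2,5-dihydroxyphenyl has hydrogen-bond donors where 4-methoxyphenyl has none, yet this difference comes with no change beyond the scatter. No measurement here explains why the number stays within the scatter.

As far as these compounds go, all three compounds keep a phenyl ring on the carbonyl carbon, so it remains open whether a ring carrying an amine or a carboxylic acid would also stay within the scatter. From the compounds shown here alone, it also remains open whether a single hydroxyl on that ring would read the same as the pair in compound 3.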